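This account rests on a few compounds, and the source may have more. Where it says the series, first, only, none or still open, it means among the compounds named here.

Working notes on the series. Among the measured compounds shown here, in a functional assay on MDA-MB-231 cells (Homo sapiens) for antiproliferative activity, read by MTT assay, with a stated time of 72 h (on this read-out lower numbers stand for stronger inhibition and higher numbers for weaker inhibition), compound 1 `COc1cccc(-c2cccc(NC(=O)CCc3ccc4c(c3)B(O)OC4)c2)c1` gives 49000 nM and compound 2 `COc1cc(OC)cc(-c2cccc(NC(=O)CCc3ccc4c(c3)B(O)OC4)c2)c1` gives 21000 nM, so compound 2 holds the lower of the only two numbers available. For the measured compounds named here, the single measured step is a 2.3-fold lower number from compound 1 to compound 2 (0.37 log units; beyond the scatter). It is modest and comes from methoxy in place of hydrogen on an aromatic carbon.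

Compound 3 `CC(=O)c1ccc(-c2cccc(NC(=O)CCc3ccc4c(c3)B(O)OC4)c2)cc1` is still unmeasured. It differs from compound 2 as follows: 4-acetylphenyl in place of 3,5-dimethoxyphenyl on an aromatic carbon. In words, this is 4-acetylphenyl in place of 3,5-dimethoxyphenyl on an aromatic carbon, meta to a large group. Going by the values given here, both methoxy groups leave, so the measured step bears on this change only in part, and nothing measured so far shows what the acetyl group does. Losing the methoxy groups points back toward compound 1 at 49000 nM, so a modest move to a higher number is the working expectation. In this assay, among the compounds with values here, the estimated step is a 2.1-fold higher number from compound 2 to compound 3 (0.33 log units; beyond the scatter), similar in size to the one measured step. For compound 3 the expected value is 45000 nM, with an estimated range of 15000 nM to 100000 nM.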

Compound 3, half-maximal inhibitory concentration: 59000 nM
Estimate against measurement, compound 3: 1.3-fold (0.12 log units) below; the measured number falls inside the stated range.
By their numbers in this assay, from the lowest: compound 2; then compounds 1 and 3 (each within the scatter of the next).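

In this assay, replacing the aryl group gives a 2.8-fold higher number from compound 2 to compound 3 (0.45 log units; beyond the scatter), so 4-acetylphenyl does not keep the lower number seen with 3,5-dimethoxyphenyl. The other new step, a 1.2-fold higher number from compound 1 to compound 3 (0.08 log units; within the scatter), leaves 4-acetylphenyl and 3-methoxyphenyl indistinguishable at this position, and of the three groups compared here, only 3,5-dimethoxyphenyl stands apart. No measurement at hand explains why these two groups read alike or why 3,5-dimethoxyphenyl differs from both.

Still open, as far as these compounds go, is whether a third methoxy group on this ring would extend the step seen with the second, or whether an amine or a carboxylic acid in place of the acetyl group would separate from the three groups compared so far. The compounds shown also leave open whether any group at this position can bring the number well below that of compound 2 at 21000 nM, since every change here has been confined to this one aryl ring on the shared core.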